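The source may report more compounds than this note shows. Statements on the series, on what has been measured and on what is new or still open speak of the compounds shown alone.

In a functional assay on the whole organism for positive allosteric modulation, with Mus musculus as the target (on this read-out higher numbers stand for an effect only at larger amounts of compound and lower numbers for an effect already at smaller amounts), compound 1, `CCC(=O)N(c1cccc(Br)c1)C1CCCC1N(C)C`, gives 0.1 mg/kg, and compound 2, `CCC(=O)N(c1ccc(Br)cc1)C1CCCC1N(C)C`, gives 2 mg/kg. Compound 2 therefore holds the higher of the two numbers, and its gap to compound 1 lies beyond the scatter. For the measured compounds named here, with only these two values in hand, it stands at the weaker end of the series so far.

Compound 3, `CCC(=O)N(c1ccc(Br)c(Br)c1)C1CCCC1N(C)C`, is compound 2 with one further substituent: bromo in place of hydrogen on an aromatic carbon. The change is bromo in place of hydrogen on an aromatic carbon, ortho to a bromo group and meta to a large group. Going by the values given here, no measured pair differs in a single place, so the size of this change has no direct precedent.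

The expectation rests on compound 1, whose 0.1 mg/kg shows that a much lower number is reachable among these bromo compounds. A moderate move toward lower numbers in this assay is expected, beyond the scatter but with real uncertainty. The expected change is a 4.0-fold lower number from compound 2 to compound 3 (0.60 log units; beyond the scatter). For compound 3 the estimated value is 0.5 mg/kg, with an expected range of 0.1 mg/kg to 2.5 mg/kg.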

Compound 3, dose for half-maximal effect: 0.1 mg/kg
For compound 3 the middle estimate is 5.0-fold (0.70 log units) above the measured one; the measured number falls inside the stated range.
By their numbers in this assay, from the lowest: compounds 1 and 3 (each within the scatter of the next); then compound 2.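

In this assay the aromatic carbon ortho to a bromo group and meta to a large group proves highly sensitive when compound 2 is the starting point, since a bromo there gives a large step (a 20-fold lower number from compound 2 to compound 3 (1.30 log units; beyond the scatter)) and no smaller shift. From the other side, the bromo that turns compound 1 into compound 3 leaves the read-out unmoved (no change at the digits printed from compound 1 to compound 3 (within the scatter)) and so adds nothing measurable there. The effect of a bromo therefore depends on what the ring already carries: compound 2 gains from the added bromo, whereas compound 1 already sits at the number that compound 3 reaches, and a second bromo offers no further lowering in these three compounds.

Nothing on hand bears on why the same kind of change gives such different steps in the two settings. Also open, from the compounds shown here alone, is whether a smaller halogen such as chloro, or a methoxy group, at this same ring carbon of compound 2 would give a comparable step, and whether the dimethylamino group and the propanoyl chain on the shared core tolerate change while this low number is kept.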